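Replacing the carboxamide-bearing pyridine with methylsulfanyl

The source may hold more compounds than are shown below. What is called first, only, known or untested is meant among the compounds shown, and "the series" means these compounds.

The series shares a core carrying a long chain ending in a phenyl group, read in an assay (Rattus norvegicus) for inhibition of Fatty-acid amide hydrolase 1 (Homo sapiens); on this read-out higher numbers stand for weaker inhibition and lower numbers for stronger inhibition. Compound 1 `Cc1cccnc1-c1cnc(C(=O)CCCCCCc2ccccc2)o1` gives 15 nM in this assay. Compound 2 `O=C(CCCCCCc1ccccc1)c1ncc(-c2ncccc2C(=O)O)o1` reaches only the limit of the assay, > 50 nM, and no number. Compound 3 `NC(=O)c1ccc(-c2cnc(C(=O)CCCCCCc3ccccc3)o2)nc1` gives 1.2 nM, the lowest of the two numbers shown; its nearest neighbour is compound 1, with a 13-fold lower number from compound 1 to compound 3 (1.10 log units; beyond the scatter). Against compound 2 the gap is an at least 41-fold lower number from compound 2 to compound 3 (1.61 log units; beyond the scatter), and from compound 1 to compound 2 the change is an at least 3.3-fold higher number from compound 1 to compound 2 (0.52 log units; beyond the scatter).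

Compound 4 `CSc1cnc(C(=O)CCCCCCc2ccccc2)o1` differs from compound 3 in one place: methylsulfanyl in place of 5-carbamoylpyridin-2-yl on an aromatic carbon. For the measured compounds named here, no measured step removes the whole six-membered ring; the two steps that bear, compound 1 to compound 3 and compound 2 to compound 3, show that the group on this carbon moves the number strongly, and compound 1 shows that even a 3-methylpyridin-2-yl sits well above compound 3. A small methylsulfanyl is therefore expected to give a markedly higher number, an estimated step of a 67-fold higher number from compound 3 to compound 4 (1.82 log units; beyond the scatter). Compound 4 is expected at about 80 nM, between 15 nM and 400 nM, with a real chance that the assay reports only a limit.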

Compound 4, inhibition constant: 25 nM
Compound 4: the middle estimate sits 3.2-fold (0.51 log units) above what was measured; measured number inside the range.
By their numbers in this assay, from the lowest: compound 3; then compounds 1 and 4 (each within the scatter of the next). At a limit, above all of these: compound 2.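

The position does not need a ring to reach this level: methylsulfanyl, with no ring, and 3-methylpyridin-2-yl cannot be told apart, with a 1.7-fold higher number from compound 1 to compound 4 (0.22 log units; within the scatter). The low number of compound 3 is therefore not something any six-membered aromatic ring on this carbon provides, and it belongs to 5-carbamoylpyridin-2-yl in particular among the groups shown, with a 21-fold higher number from compound 3 to compound 4 (1.32 log units; beyond the scatter). The comparison with the carboxy-bearing compound gives only a floor, an at least 2.0-fold lower number from compound 2 to compound 4 (0.30 log units; that floor lies within the scatter), and it cannot be read as a size because compound 2 stands at a limit and not at a number: the limit of > 50 nM in this assay, at which 1 of the 4 values shown sits.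

The compounds shown do not separate the contribution of the carboxamide from that of the pyridine ring in compound 3, and an unsubstituted pyridin-2-yl or a phenyl ring carrying the same carboxamide would bear directly on that. Going by these compounds, it also remains open whether the sulfur of methylsulfanyl matters at this carbon, as a plain methyl, a methoxy or an amine in its place would show.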